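Phenyl for pyridazinyl on the ring nitrogen: stability outlook

The source may report more compounds than this note shows. Statements on the series, on what has been measured and on what is new or still open speak of the compounds shown alone.

Compound 2 `Cc1ccncc1-c1cccc2c1cnn2-c1cccnn1` carries a pyridazin-3-yl group on an aromatic nitrogen of the shared core. In an ADME assay on liver (Macaca fascicularis) for metabolic stability, using microsomes, with a stated time of 10 min, tested at 0.5 uM (a lower number here means that less of the compound is left, a higher number that more of the compound is left), compound 2 gives "not determined" (no result reported), so no number stands for it. The same holds for compound 1 `Cc1ccncc1-c1cccc2c1cnn2-c1nccs1`, for which this assay reports "not determined" (no result reported). Among the measured compounds shown here, the only number belongs to compound 3 `Cc1ccncc1-c1cccc2c1ncn2-c1cnccn1`, whose core differs from that of compound 2; in this assay compound 3 gives 83%.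

Compound 4 `Cc1ccncc1-c1cccc2c1cnn2-c1ccccc1` arises from compound 2 by the change (phenyl in place of pyridazin-3-yl on an aromatic nitrogen). For the measured compounds named here, no measured pair of this kind exists in the set, so the size of the step in this assay is not known; the direction is open, and a move of either sign beyond the scatter or none at all is possible. Given only the single number from compound 3, compound 4 is expected to retain 60% of the compound, within a range of 25% to 90%.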

Compound 4, percent of the compound remaining: 39%
Estimate against measurement, compound 4: 21 percentage points above; measured number inside the range.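

In this assay compound 2 gives "not determined" (no result reported) and compound 4 gives 39%, so no step can be read between them. The compounds shown leave open what phenyl in place of pyridazin-3-yl does to the percentage remaining. No supporting evidence bears on this result.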